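Amide-linked carboxylic acid replacing imidazole in a kinase activator

The source may hold more compounds than are shown below. What is called first, only, known or untested is meant among the compounds shown, and "the series" means these compounds.

Compound 1 `OC[C@@H](O[C@H]1CCCN(Cc2ncc[nH]2)[C@H]1c1ccccc1)c1cc(Cl)cc(Cl)c1` is the weakest of the three measured compounds in an assay on isolated protein for activation of cGMP-dependent protein kinase 1 (Homo sapiens), read by ADP-Glo, with stated times of 30 min and 2 h, in the presence of a further agent that is not named here (a lower number here means that less compound is needed, a higher number that more compound is needed for the effect), giving 47000 nM. Compound 2 `O=C(O)c1ccc2nc(CN3CCC[C@H](O[C@H](CO)c4cc(Cl)cc(Cl)c4)[C@@H]3c3ccccc3)[nH]c2c1` gives 380 nM, and compound 3 `O=C(O)c1ccc(CN2CCC[C@H](O[C@H](CO)c3cc(Cl)cc(Cl)c3)[C@@H]2c2ccccc2)c([N+](=O)[O-])c1` gives 520 nM; between those two the difference is a 1.4-fold higher number from compound 2 to compound 3 (0.14 log units; within the scatter). Compound 4 `Cc1cc(C(=O)O)ccc1C(=O)N1CCC[C@H](O[C@H](CO)c2cc(Cl)cc(Cl)c2)[C@@H]1c1ccccc1` has not yet been measured. Its change from compound 1 is a group of 12 heavy atoms (9 carbon, 3 oxygen; one six-membered aromatic ring of carbon only) in place of a group of 6 heavy atoms (4 carbon, 2 nitrogen; one five-membered aromatic ring with 2 hetero atoms), on an amine nitrogen in a ring. The measured steps that bear on this are a 120-fold lower number from compound 1 to compound 2 (2.09 log units; beyond the scatter) and a 90-fold lower number from compound 1 to compound 3 (1.96 log units; beyond the scatter), in both of which a carboxylic acid on an aromatic ring enters where the imidazole stood. Within the data shown here, compound 4 also brings in a carboxylic acid on a benzene ring, but through a carbonyl on the ring nitrogen rather than a chain carbon, a change no measured pair covers, so the gain is less certain. A large drop is still expected, estimated as a 31-fold lower number from compound 1 to compound 4 (1.50 log units; beyond the scatter). The expected value for compound 4 in this assay is 1500 nM, with a range from 300 nM to 8000 nM.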

Compound 4, half-maximal effective concentration: > 200000 nM
Compound 4: only a limit was reported; the forecaster's own chance of this, stated with the estimate: 5%; middle value at least 130-fold (2.12 log units) away from the limit.
By their numbers in this assay, from the lowest: compounds 2 and 3 (each within the scatter of the next); then compound 1. At a limit, above all of these: compound 4.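

Compound 4 gives only a limit of the assay, not a number: the limit of > 200000 nM in this assay, at which 1 of the 4 values shown sits.

Among these compounds, at the amine nitrogen in the ring, this change moves the opposite way from the earlier ones, with an at least 4.2-fold higher number from compound 1 to compound 4 (0.62 log units; beyond the scatter), whereas the earlier steps were a 120-fold lower number from compound 1 to compound 2 (2.09 log units; beyond the scatter) and a 90-fold lower number from compound 1 to compound 3 (1.96 log units; beyond the scatter). A carboxylic acid on a benzene ring therefore does not bring the gain by itself: compounds 2 and 3 show it with a saturated chain carbon on that nitrogen, and compound 4, with a carbonyl there, goes against it.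

The compounds shown do not separate the carbonyl from the other differences in the entering group, such as the methyl on its benzene ring. A benzoyl group without that methyl, or an imidazole-2-carbonyl group on the same nitrogen, would bear directly on this question.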